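This account rests on a few compounds, and the source may have more. Where it says the series, first, only, none or still open, it means among the compounds named here.

Compound 1 `O=C(/C=C/c1ccc(O)cc1)c1ccc2occc2c1O` and compound 2 `O=C(/C=C/c1ccc(O)c(O)c1)c1ccc2occc2c1O` share one core, and in an assay on isolated protein for inhibition of lysosomal alpha-glucosidase (Rattus norvegicus), read by spectrophotometry, with a stated time of 5 min, tested at 25 ug/mL (on this read-out higher numbers stand for more inhibition at the one concentration tested (going by the name of the read-out) and lower numbers for less inhibition), compound 1 gives 65.7% while compound 2 gives 61.5%. Within the data shown here, the single measured step, a number 4.2 percentage points lower from compound 1 to compound 2 (within the scatter), comes from putting hydroxy in place of hydrogen on an aromatic carbon. On these two numbers compound 2 stands with the lower value, though within the scatter of compound 1. Compound 3 `COc1cc(/C=C/C(=O)c2ccc3occc3c2O)ccc1O` differs from compound 2 by methyl in place of hydrogen on an oxygen on an aromatic ring. Among the measured compounds shown here, only the step from compound 1 to compound 2 bears on this change, and it stayed within the scatter, so no step beyond the scatter is expected in this assay. The estimated step is a number 2.5 percentage points lower from compound 2 to compound 3 (within the scatter). Compound 3 is therefore expected to give about 59%, in the range 44% to 74%.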

Compound 3, a percentage reported as inhibition, at one concentration (the size of the read-out at that concentration, not a potency): 45%
The estimate for compound 3 lay 14 percentage points above the measured number; the measured number falls inside the stated range.
By their numbers in this assay, from the lowest: compound 3; then compounds 2 and 1 (each within the scatter of the next).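

In this assay, methyl in place of hydrogen on an oxygen on an aromatic ring gives a number 16.5 percentage points lower from compound 2 to compound 3 (beyond the scatter) and so moves the number beyond the scatter, which the earlier hydroxy step did not do. Set against compound 1, the added methoxy gives a number 20.7 percentage points lower from compound 1 to compound 3 (beyond the scatter) in the same direction, so here the methoxy and the free hydroxy do not read alike. Nothing available explains this drop. The compounds shown leave open whether ethoxy, a longer chain on that oxygen, or an amine in place of the hydroxy would read like compound 2 or like compound 3.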